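The source may report more compounds than this note shows. Statements on the series, on what has been measured and on what is new or still open speak of the compounds shown alone.

The series shares one core. Compound 1 `O=S(=O)(Nc1ccc(Cl)c(F)c1)c1ccc(-c2cnc(C3CC3)o2)cc1` carries a 4-chloro-3-fluorophenyl on the sulfonamide nitrogen; in a functional assay on cells (leukaemia cell line, Homo sapiens) for inhibition, read by sulforhodamine B assay, with a stated time of 48 h (on this read-out higher numbers stand for weaker inhibition of growth and lower numbers for stronger inhibition of growth), compound 1 gives 380 nM, the highest of the three numbers measured. Compound 2 `Cc1cc(NS(=O)(=O)c2ccc(-c3cnc(C4CC4)o3)cc2)ccc1Cl` gives 216 nM in this assay, and the step of a 1.8-fold lower number from compound 1 to compound 2 (0.25 log units; within the scatter) stays within the scatter, so methyl in place of fluoro on the aromatic carbon does not move the read-out. Compound 3 `Cc1ccc(Cl)c(NS(=O)(=O)c2ccc(-c3cnc(C4CC4)o3)cc2)c1` gives 48.8 nM; the steps of a 7.8-fold lower number from compound 1 to compound 3 (0.89 log units; beyond the scatter) and a 4.4-fold lower number from compound 2 to compound 3 (0.65 log units; beyond the scatter) are both beyond the scatter, and both involve 2-chloro-5-methylphenyl entering on the sulfonamide nitrogen. Compound 4 `O=S(=O)(Nc1ccc(I)c(Cl)c1)c1ccc(-c2cnc(C3CC3)o2)cc1` is not yet measured; it differs from compound 1 by 3-chloro-4-iodophenyl in place of 4-chloro-3-fluorophenyl on a sulfonamide nitrogen. Going by the values given here, no measured step brings in iodo, and the only step that swaps one substituent for another without the 2-chloro-5-methylphenyl, a 1.8-fold lower number from compound 1 to compound 2 (0.25 log units; within the scatter), is within the scatter. The expected step is therefore a 1.5-fold lower number from compound 1 to compound 4 (0.16 log units; within the scatter), not beyond the scatter in this assay. Compound 4 is estimated at 260 nM, with a range from 100 nM to 700 nM.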

Compound 4, concentration for 50% growth inhibition: 1010 nM
Compound 4: middle estimate off by 3.9-fold (0.59 log units), on the low side; the measured number lies above the stated range.
By their numbers in this assay, from the lowest: compound 3; then compounds 2 and 1 (each within the scatter of the next); then compound 4.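

Going by these compounds alone, on the sulfonamide nitrogen, 3-chloro-4-iodophenyl is the only group among the four that raises the number relative to 4-chloro-3-fluorophenyl in this assay, with a 2.7-fold higher number from compound 1 to compound 4 (0.42 log units; beyond the scatter) as the step. Within the data shown here, it also falls behind both methyl-bearing groups, with a 4.7-fold higher number from compound 2 to compound 4 (0.67 log units; beyond the scatter) for 4-chloro-3-methylphenyl and a 21-fold higher number from compound 3 to compound 4 (1.32 log units; beyond the scatter) for 2-chloro-5-methylphenyl, so the swap of one aryl group for another at this position can move the read-out in either direction and over a wider span than the earlier compounds showed. Nothing measured here accounts for this rise.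

Compound 4 differs from compound 1 in both ring substituents at once, so the shares of the iodo and of the moved chloro remain unseparated. Also open, from the compounds shown here alone, is how this position responds to a phenyl bearing an amine or a carboxylic acid in place of the halogens.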